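The source may hold more compounds than are shown below. What is called first, only, known or untested is meant among the compounds shown, and "the series" means these compounds.

Compound 1, `O=c1c(SC(=S)N2CCCCC2)coc2ccccc12`, gives 16300 nM in a functional assay on SW480 cells (Homo sapiens) for antiproliferative activity, read by MTT assay, with a stated time of 72 h; a higher number here means a weaker inhibitor, a lower number a stronger inhibitor.
Compound 2, `CC(C)N(C(=S)SCc1cc(=O)c2ccc(Cl)cc2o1)C(C)C`, gives in this assay only a limit of the assay, > 25000 nM.
Compound 3, `O=c1c(SC(=S)N2CCCCC2)coc2ccc(Cl)cc12`, gives in this assay likewise only a limit of the assay, > 25000 nM.

Two of the three values therefore sit at the limit of > 25000 nM in this assay, at which 2 of the 3 values shown sit, and only compound 1 yields a number. Compound 1 and compound 3 share one core and differ in a single place: hydrogen in place of chloro on an aromatic carbon. That change produced an at least 1.5-fold lower number from compound 3 to compound 1 (0.18 log units; that floor lies within the scatter), a step whose lower floor lies within the usual scatter of such measurements, so the direction is all that can be read from it. Compound 2 is built on another core; the difference between the two cores is not broken down here.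

Compound 4, `CC(C)N(C(=S)SCc1cc(=O)c2ccccc2o1)C(C)C`, has not yet been measured in this assay. It stands to compound 2 exactly as compound 1 stands to compound 3: hydrogen in place of chloro on an aromatic carbon. The two place descriptions agree word for word, so this is the same change made on the second core.

The expected step from compound 2 to compound 4 in this assay is an at least 1.3-fold lower number from compound 2 to compound 4 (0.14 log units; that floor lies within the scatter), about the size seen in the earlier pair, because that pair gave an at least 1.5-fold lower number from compound 3 to compound 1 (0.18 log units; that floor lies within the scatter) and because compound 2 starts at the limit of > 25000 nM in this assay, at which 2 of the 3 values shown sit. Compound 4 is thus estimated at 18000 nM, expected to fall between 8000 nM and 50000 nM, with a real chance that only a limit is reported.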

Compound 4, half-maximal inhibitory concentration: > 40000 nM
Compound 4: a limit, no number; the forecaster's own chance of this, stated with the estimate: 45%; middle value at least 2.2-fold (0.34 log units) from the limit.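

Compound 4 gives in this assay only a limit of the assay, > 40000 nM. Compound 2 likewise gives only a limit, > 25000 nM. With a limit on each side, the step from compound 2 to compound 4 cannot be read. The compounds shown leave open whether hydrogen in place of chloro acts on this second core as it does on the core of compound 1.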